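The compounds below may be only part of what the source reports. "The series", "measured", "known", "first", "only" and "open" are said of these compounds alone.

Series notes. Compound 1 `CC(C(=O)NCc1ccc(C(F)(F)F)nc1N(C)C)c1ccc(NS(C)(=O)=O)c(F)c1` gives 19.1 nM in a functional assay on CHO-K1 cells for antagonist activity at transient receptor potential cation channel subfamily V member 1 (Homo sapiens), read by FLIPR; on this read-out higher numbers stand for weaker inhibition and lower numbers for stronger inhibition; compound 2 `CC(C(=O)NCc1ccc(C(F)(F)F)nc1N1CCC(C(=O)c2ccc(F)cc2)CC1)c1ccc(NS(C)(=O)=O)c(F)c1` gives 3.9 nM; compound 3 `CC(C(=O)NCc1ccc(C(F)(F)F)nc1N1CCC(C(F)(F)F)CC1)c1ccc(NS(C)(=O)=O)c(F)c1` gives 0.6 nM, the lowest of the three numbers, reached by a 32-fold lower number from compound 1 to compound 3 (1.50 log units; beyond the scatter) and by a 6.5-fold lower number from compound 2 to compound 3 (0.81 log units; beyond the scatter). Compound 4 `CC(C(=O)NCc1ccc(C(F)(F)F)nc1N1CCC(O)CC1)c1ccc(NS(C)(=O)=O)c(F)c1` carries the change (hydroxy in place of trifluoromethyl on a saturated ring carbon). The step that bears most directly on it sits at the same saturated ring carbon, a 6.5-fold lower number from compound 2 to compound 3 (0.81 log units; beyond the scatter), modest in size; the larger step, a 32-fold lower number from compound 1 to compound 3 (1.50 log units; beyond the scatter), exchanges the whole ring and is less direct. In both steps the number fell when trifluoromethyl entered, so on its replacement a modest move upward is expected, a 6.7-fold higher number from compound 3 to compound 4 (0.82 log units; beyond the scatter). Compound 4 is therefore estimated at 4 nM, with a range of 1.2 nM to 15 nM.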

Compound 4, inhibition constant: "not active" (no number reported)
The entry for compound 4 holds no number; the estimate stays without a comparison.
By their numbers in this assay, from the lowest: compound 3; then compound 2; then compound 1.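

Going by these compounds alone, compound 4 is entered as "not active" with no number, so no step from compound 3 to compound 4 can be read. The compounds shown leave open where 4-hydroxypiperidin-1-yl falls numerically relative to 4-(trifluoromethyl)piperidin-1-yl. Nothing at hand accounts for this entry.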